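Estimating a benzyl swap in a cell toxicity assay

The source may report more compounds than this note shows. Statements on the series, on what has been measured and on what is new or still open speak of the compounds shown alone.

Compound 1 `COc1ccc2cc([C@H](C)c3nnc(SCc4c(C)cc(C)cc4C)n3-c3cccc(Cl)c3)ccc2c1` gives <= 400000 nM (a limit)
Compound 2 `COc1cccc(CSc2nnc([C@@H](C)c3ccc4cc(OC)ccc4c3)n2-c2ccc(Cl)cc2)c1` gives 162000 nM

For the measured compounds named here, in a functional assay on LNCaP cells (Homo sapiens) for cytotoxicity, read by MTT assay (on this read-out lower numbers stand for stronger inhibition and higher numbers for weaker inhibition), compound 2 gives 162000 nM as the only true number so far. Compound 1 gives <= 400000 nM which is a limit of the assay and not a number.

Going by the values given here, compound 3 `COc1ccc2cc([C@H](C)c3nnc(SCc4ccc(F)cc4)n3-c3ccc(Cl)cc3)ccc2c1` carries 4-fluorophenyl in place of 3-methoxyphenyl on a saturated chain carbon bound to a sulfur as its one change. Among the compounds with values here, no measured step shows what such a swap does, so compound 2 at 162000 nM is the sole anchor. The expected 1.2-fold lower number from compound 2 to compound 3 (0.10 log units; within the scatter) stays within the usual scatter and has no firm direction. The estimate for compound 3 is 130000 nM with an expected range from 50000 nM to 350000 nM in this assay once measured.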

Compound 3, half-maximal inhibitory concentration: 33900 nM
Compound 3: the middle estimate sits 3.8-fold (0.58 log units) above what was measured, outside the stated range (below it).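

In this assay putting 4-fluorophenyl in place of 3-methoxyphenyl on a saturated chain carbon bound to a sulfur gives a 4.8-fold lower number from compound 2 to compound 3 (0.68 log units; beyond the scatter) and so marks this position as one where a change shows in the read-out. For the compounds shown here, the earlier compounds offered no step to read here, so this is the first measured sign of it. Nothing measured here accounts for the size of this step.

Fluorine arrives as the methoxy group leaves, so the share of each remains unknown. As far as these compounds go, how an amine, a carboxylic acid or a longer chain would fare at this position also remains open.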